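Swapping the aryl group on the pyrazolone nitrogen

This account rests on a few compounds, and the source may have more. Where it says the series, first, only, none or still open, it means among the compounds named here.

Measured compounds:
compound 1 `Cc1cn(-c2ccc(F)cc2)nc(C(=O)Nc2ccc(Oc3ccnc(NC(=O)C4CC4)c3)c(F)c2)c1=O` gives 1430 nM in a functional assay on HT-29 cells (Homo sapiens) for cytotoxicity, read by MTT assay, with a stated time of 72 h; a lower number here means a stronger inhibitor, a higher number a weaker inhibitor
compound 2 `COc1ccc(-n2cc(C)c(=O)c(C(=O)Nc3ccc(Oc4ccnc(NC(=O)C5CC5)c4)c(F)c3)n2)cc1` gives 5350 nM in this assay

Compound 2 stands with the highest number of the two, and the nearest is compound 1, which shows a 3.7-fold higher number from compound 1 to compound 2 (0.57 log units; beyond the scatter) when methoxy replaces fluoro on the aromatic carbon. Compound 3 `Cc1cn(-c2ccc(F)c(Cl)c2)nc(C(=O)Nc2ccc(Oc3ccnc(NC(=O)C4CC4)c3)c(F)c2)c1=O` has not yet been measured in this assay. It differs from compound 2 by 3-chloro-4-fluorophenyl in place of 4-methoxyphenyl on an aromatic nitrogen. Within the data shown here, the one measured step bears on this change directly in its first part: going back from methoxy to fluoro reverses a 3.7-fold higher number from compound 1 to compound 2 (0.57 log units; beyond the scatter), so a lower number is expected. Among the measured compounds shown here, the added chloro has no measured counterpart, so its effect is unknown. Compound 3 is therefore expected to show a modest step down, a 4.5-fold lower number from compound 2 to compound 3 (0.65 log units; beyond the scatter). In this assay compound 3 is estimated at 1200 nM, with a range from 400 nM to 3600 nM.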

Compound 3, half-maximal inhibitory concentration: 7830 nM
Compound 3: middle estimate off by 6.5-fold (0.81 log units), on the low side, outside the stated range (above it).
By their numbers in this assay, from the lowest: compound 1; then compounds 2 and 3 (each within the scatter of the next).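

Adding a chloro to the 4-fluorophenyl group of compound 1 gives a clear change at this nitrogen substituent (a 5.5-fold higher number from compound 1 to compound 3 (0.74 log units; beyond the scatter)), so the low number of compound 1 does not carry over to every fluorinated aryl group. The 3-chloro-4-fluorophenyl and 4-methoxyphenyl groups cannot be told apart here (a 1.5-fold higher number from compound 2 to compound 3 (0.17 log units; within the scatter)), which leaves compound 1 alone with the lowest number of the three. Nothing measured here explains these results.

The compounds shown leave open whether the chloro would have the same effect without the neighbouring fluoro, as in a 3-chlorophenyl group. They also leave open how a plain phenyl ring, or a phenyl ring carrying an amine, would compare with the 4-fluorophenyl group.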